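From fluoro to hydrogen on a shared core

The compounds below may be only part of what the source reports. "The series", "measured", "known", "first", "only" and "open" are said of these compounds alone.

Measured in a physicochemical assay for lipophilicity, at pH 7.4; a higher number here means a more lipophilic compound, a lower number a more polar compound:
Compound 1 `COc1ccc(Cc2c[nH]c(C(=O)NC3CC3)c2C)c2cnccc12`: < 3.4
Compound 2 `Cc1c(Cc2ccc(F)c3ccncc23)c[nH]c1C(=O)NC1CC1`: < 3.4

Compound 2 has no exact value, since its < 3.4 is a limit of the assay and not a number. Compound 1 also gives only a limit, < 3.4. The two compounds therefore stand together at one reading: the limit of < 3.4 in this assay, at which 2 of the 2 values shown sit.

Compound 3 `Cc1c(Cc2cccc3ccncc23)c[nH]c1C(=O)NC1CC1` has not yet been measured. It differs from compound 2 by one small change: hydrogen in place of fluoro on an aromatic carbon.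

Among the compounds with values here, only one measured step bears on this change, namely a step that the two limits leave unreadable from compound 1 to compound 2, with fluoro in place of methoxy on an aromatic carbon. That step has no readable size, so it offers no guide to the size or direction of the next one. From the compounds shown here alone, no shift beyond the scatter is therefore expected in this assay, and the direction remains open. The expected change is a step that the limit leaves unreadable from compound 2 to compound 3. For compound 3 the estimated value is 2.9, with an expected range from 2.4 to 3.3.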

Compound 3, distribution coefficient: < 3.4
Compound 3: no number, only a limit (the forecaster's own chance of this, stated with the estimate: 70%); the middle value does not contradict the limit.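

In this assay compound 3 gives < 3.4, which is a limit of the assay and not a number. Within the data shown here, no step among compound 1, compound 2 and compound 3 can be read, and all three share one reading: the limit of < 3.4 in this assay, at which 3 of the 3 values shown sit. The compounds shown leave open whether methoxy, fluoro or hydrogen on that aromatic carbon changes the distribution coefficient at all, and in which direction.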